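Isopropyl for fluoro on the benzyl group of compound 2

The source may report more compounds than this note shows. Statements on the series, on what has been measured and on what is new or still open speak of the compounds shown alone.

Two compounds have been run in an assay on CHO cells for displacement of a labelled ligand from melanin-concentrating hormone receptor 1 (Rattus norvegicus), read by scintillation counting, with a stated time of 1 h; on this read-out higher numbers stand for weaker inhibition and lower numbers for stronger inhibition. Compound 1 `Cc1oc2ccc(NC(=O)COc3ccc(OC(F)(F)F)cc3)cc2c1C` is built on a different core. In this assay compound 1 gives only a limit, > 1000 nM, and the limit of > 1000 nM in this assay, at which 1 of the 2 values shown sits, marks where that limit sits. Compound 2 `Cc1c(C2CC2)nc2ccc(-n3ccc(OCc4ccc(F)cc4)cc3=O)cn12` is the one compound with a numerical result: in this assay compound 2 gives 28 nM, the only number shown. Compound 3 `Cc1c(C2CC2)nc2ccc(-n3ccc(OCc4ccc(C(C)C)cc4)cc3=O)cn12` has not yet been measured. It differs from compound 2 by isopropyl in place of fluoro on an aromatic carbon. For the measured compounds named here, no step between two measured compounds differing in a single place is available, so no direction can be read from the data. The step from compound 2 to compound 3 is expected to be modest, a 1.8-fold higher number from compound 2 to compound 3 (0.25 log units; within the scatter), a slight loss that need not clear the scatter. Compound 3 is expected to give 50 nM in this assay, with a range from 12 nM to 250 nM.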

Compound 3, half-maximal inhibitory concentration: 240 nM
Beside the measured number, compound 3's estimate is 4.8-fold (0.68 log units) below it; the range from low to high includes it.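

For the compounds shown here, the first step in one place falls on the benzyl group: in this assay, 4-fluorobenzyl to 4-isopropylbenzyl gives an 8.6-fold higher number from compound 2 to compound 3 (0.93 log units; beyond the scatter) in this series. This position on the aromatic ring, para to a large group, is therefore not indifferent to what it carries, although compound 3 at 240 nM still gives a numerical result on the shared core. Nothing measured on these compounds accounts for the loss.

A single step at this position gives two points and no trend across groups. Where a chloro, a methoxy or an amine at the same place would fall relative to fluoro and isopropyl remains open, as does whether the same exchange would carry the same penalty on the core of compound 1.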